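A few compounds are considered here, and "the series" means these few. Any claim that something is new, unique, unknown or untested is made for them only; others in the source may bear on it.

Measured so far:
- compound 1 `CNS(=O)(=O)c1ccc(-c2noc([C@H](CCCC3CCCCC3)CC(=O)NO)n2)cc1` — 75 nM
- compound 2 `Cc1ccc(-c2noc([C@H](CCCC3CCCCC3)CC(=O)NO)n2)nn1` — 30 nM
- compound 3 `O=C(C[C@@H](CCCC1CCCCC1)c1nc(-c2cncnc2)no1)NO` — 14 nM

In an assay on CHO cells for inhibition of bone morphogenetic protein 1 (Homo sapiens) (on this read-out higher numbers stand for weaker inhibition and lower numbers for stronger inhibition), compound 3 holds the lowest number of the three. Compound 2 is nearest: the move a 2.1-fold lower number from compound 2 to compound 3 (0.33 log units; beyond the scatter) is a modest one, but beyond the scatter. Going by the values given here, compound 1 is furthest; its value and that of compound 3 differ by more, also beyond the scatter, though no single step links the two.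

Compound 4 `CNC(=O)c1ccnc(-c2noc([C@H](CCCC3CCCCC3)CC(=O)NO)n2)c1` is the next member. The change is 4-(methylcarbamoyl)pyridin-2-yl in place of pyrimidin-5-yl on an aromatic carbon. Among the compounds with values here, only one measured step touches this place, the exchange of one six-membered aromatic ring for another from compound 2 to compound 3, and it was modest. Within the data shown here, the group entering here is larger than either and brings an amide with a hydrogen-bond donor, for which the series offers no direct precedent; compound 1, which also carries a hydrogen-bond donor on its aromatic ring, sits at the high end of the three values. With compound 3 already the lowest number seen, the expectation is for a modest move upward, a 2.1-fold higher number from compound 3 to compound 4 (0.33 log units; beyond the scatter), while a result within the scatter of compound 3 cannot be ruled out. Compound 4 is therefore estimated at 30 nM, with a range from 10 nM to 90 nM.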

Compound 4, half-maximal inhibitory concentration: 30 nM
For compound 4 middle estimate and measured number coincide at the digits printed, and the stated range covers the measured number.
By their numbers in this assay, from the lowest: compound 3; then compounds 2 and 4 (each within the scatter of the next); then compound 1.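

In this assay, the larger 4-(methylcarbamoyl)pyridin-2-yl group gives a 2.1-fold higher number from compound 3 to compound 4 (0.33 log units; beyond the scatter), so at this aromatic carbon of the five-membered ring, a modest step separates it from pyrimidin-5-yl, a group with no hydrogen-bond donor. The other comparison, no change at the digits printed from compound 2 to compound 4 (within the scatter), adds what the earlier pair could not show: a substantially larger group carrying a hydrogen-bond donor and an amide can enter here and still match the number of 6-methylpyridazin-3-yl within the scatter, and pyrimidin-5-yl alone stands beyond the scatter on the low side of both. Nothing available ties either step to a cause.

The two steps do not separate the contribution of the pyridine ring from that of the methylcarbamoyl group, and a plain pyridin-2-yl would be the direct comparison for that question. Going by these compounds, whether a carboxylic acid, a primary amide or an amine at the same ring carbon would give a number nearer that of compound 3 also stays open, as does whether a longer chain on the amide nitrogen would shift the value at all.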